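Piperazine in place of the thioether of compound 2

The compounds below may be only part of what the source reports. "The series", "measured", "known", "first", "only" and "open" are said of these compounds alone.

Compound 1 `Cn1c(-c2ccc(NC(=O)CSc3nc4cc(Cl)ccc4o3)cc2)nc(-c2ccccc2)c1-c1ccccc1`: 61.9%
Compound 2 `Cn1c(-c2ccc(NC(=O)CSC3=NCCS3)cc2)nc(-c2ccccc2)c1-c1ccccc1`: 59.4%

In a functional assay on HT-29 cells (Homo sapiens) for cytotoxicity, read by MTT assay, with a stated time of 24 h, tested at 32 ug/mL (on this read-out lower numbers stand for a weaker effect and higher numbers for a stronger effect at the one concentration tested), compound 2 gives 59.4%, the lower of the two numbers, yet the gap to compound 1 is within the scatter, as a number 2.5 percentage points lower from compound 1 to compound 2 (within the scatter) shows. Compound 3 `CN(C)/C=C/N1CCN(CC(=O)Nc2ccc(-c3nc(-c4ccccc4)c(-c4ccccc4)n3C)cc2)CC1` differs from compound 2 in one place: a group of 11 heavy atoms (8 carbon, 3 nitrogen; one six-membered non-aromatic ring with 2 hetero atoms) in place of a group of 6 heavy atoms (3 carbon, 1 nitrogen, 2 sulfur; one five-membered non-aromatic ring with 2 hetero atoms), on a saturated chain carbon bound to a carbonyl carbon. Going by the values given here, the only measured step changed the group on the sulfur, not this carbon, and stayed within the scatter, so nothing bears directly on the change. For compound 3 the expected step is a number 2.4 percentage points lower from compound 2 to compound 3 (within the scatter), none beyond the scatter. Compound 3 is therefore estimated at 57%, between 35% and 75%.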

Compound 3, a percentage reported as activity, at one concentration (the size of the read-out at that concentration, not a potency): 29.8%
Compound 3: middle estimate off by 27.2 percentage points, on the high side; measured number below the stated range.
By their numbers in this assay, from the lowest: compound 3; then compounds 2 and 1 (each within the scatter of the next).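

At the saturated chain carbon bound to a carbonyl carbon, 4-(2-(dimethylamino)ethenyl)piperazin-1-yl gives in this assay a number 29.6 percentage points lower from compound 2 to compound 3 (beyond the scatter) and a number 32.1 percentage points lower from compound 1 to compound 3 (beyond the scatter) against the sulfur-linked groups, whereas the change on the sulfur stayed within the scatter. This position therefore tolerates less than the sulfur substituent alone suggested: replacing the whole sulfur-linked group does change the read-out. Nothing at hand gives a reason for this.

Going by these compounds, whether the piperazine ring or its 2-(dimethylamino)ethenyl group carries the loss remains open. So does what an unsubstituted piperazine, a morpholine or a simple dimethylamino group would give at this carbon.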